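Swapping bromo for (propylamino)methyl on a shared core

This account rests on a few compounds, and the source may have more. Where it says the series, first, only, none or still open, it means among the compounds named here.

Of the compounds shown here, two of a common core have been measured so far. Compound 1 `CCCNC(=O)C1CCN(C(=O)c2cc3sc(CO)cc3n2Cc2ccc(OC)cc2)CC1` and compound 2 `CCCNC(=O)C1CCN(C(=O)c2c(Br)c3sccc3n2Cc2ccc(OC)cc2)CC1` were tested in an ADME assay on HEK-293T cells (Homo sapiens) for cytotoxicity, read by luminescence, with a stated time of 24 h; on this read-out lower numbers stand for higher toxicity in this test and higher numbers for lower toxicity in this test. In this assay compound 1 gives 15500 nM, and compound 2 gives 31600 nM, the higher of the two numbers; the gap between compound 1 and compound 2 lies beyond the usual scatter. Compound 3 `CCCNCc1c(C(=O)N2CCC(C(=O)NCCC)CC2)n(Cc2ccc(OC)cc2)c2ccsc12` differs from compound 2 in one place: (propylamino)methyl in place of bromo on an aromatic carbon. Going by the values given here, no measured pair shows a change of this kind, so there is no step in the data on which to rest a direction. Compound 3 is therefore expected to land in the same region as compound 2 in this assay, with a step of a 1.6-fold lower number from compound 2 to compound 3 (0.20 log units; within the scatter) that is estimated not to exceed the scatter by much. For compound 3 the estimate in this assay is 20000 nM, with a range from 7000 nM to 60000 nM.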

Compound 3, half-maximal cytotoxic concentration: > 100000 nM
Compound 3 ended at the assay's limit; the forecaster's own chance of this, stated with the estimate: 20%; at least 5.0-fold (0.69 log units) between middle value and limit.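

On the aromatic carbon of the five-membered ring, in this assay, (propylamino)methyl in place of bromo gives an at least 3.1-fold higher number from compound 2 to compound 3 (0.50 log units; beyond the scatter), so this position takes the larger group with no rise in toxicity in this test, and the change moves the number up rather than leaving it in place. For compound 3, > 100000 nM is a limit of the assay and not a number. The step can therefore be read only as a lower bound, because compound 3 sits at that limit: the limit of > 100000 nM in this assay, at which 1 of the 3 values shown sits.

This single pair cannot separate the loss of bromo from the gain of the amine side chain. As far as these compounds go, whether a plain methyl, a shorter aminomethyl or a carboxylic acid on this carbon would also reach the limit remains open.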